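This account rests on a few compounds, and the source may have more. Where it says the series, first, only, none or still open, it means among the compounds named here.

Going by the values given here, compound 3 `CC/C=C/C(=O)Nc1cccc(Oc2nc(Nc3cccc(C#N)c3)nc3ccsc23)c1` holds the larger of the two numbers so far reported in a functional assay on HeLa cells (Homo sapiens) for inhibition, read by MTT assay, with a stated time of 72 h; a higher number here means a weaker inhibitor, a lower number a stronger inhibitor; compound 3 gives 69400 nM there. Its nearest neighbour is compound 1 `COc1ccc(Nc2nc(Oc3cccc(NC(=O)/C=C/C(C)C)c3)c3sccc3n2)cc1`, which in this assay gives 45100 nM, a gap that lies within the scatter. Compound 2 `COc1ccc(Nc2nc(Oc3cccc(NC(=O)/C=C/C(C)C)c3)c3sccc3n2)cn1` in this assay reaches only the limit > 50000 nM. That value is one of the limit of > 50000 nM in this assay, at which 1 of the 3 values shown sits. Among the compounds with values here, the single measured step, an at least 1.1-fold higher number from compound 1 to compound 2 (0.04 log units; that floor lies within the scatter), concerns the methoxy-bearing aryl on the nitrogen and sits at the floor of what the scatter allows. The unmeasured compound 4 `CC(C)/C=C/C(=O)Nc1cccc(Oc2nc(Nc3cccc(C#N)c3)nc3ccsc23)c1` differs from compound 3 in that (methyl in place of hydrogen on a saturated chain carbon bound to a double-bonded chain carbon and a saturated chain carbon). Within the data shown here, no measured step touches this change; compound 1 carries the same 3-methylbut-1-en-1-yl group as compound 4, and its number stands within the scatter of compound 3. The step is therefore expected to be no larger than the scatter, a 1.2-fold lower number from compound 3 to compound 4 (0.06 log units; within the scatter). Compound 4 is estimated at 60000 nM in this assay, within 25000 nM to 150000 nM.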

Compound 4, half-maximal inhibitory concentration: 36500 nM
Estimate against measurement, compound 4: 1.6-fold (0.22 log units) above; the range from low to high includes it.
By their numbers in this assay, from the lowest: compounds 4, 1 and 3 (each within the scatter of the next).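

Set against compound 3, the isopropyl end of compound 4 gives the first measured size for ethyl to isopropyl at this saturated chain carbon: a 1.9-fold lower number from compound 3 to compound 4 (0.28 log units; within the scatter) in this assay, a change that stays inside the scatter. With the 3-methylbut-1-en-1-yl group held constant, 3-cyanophenyl in place of 4-methoxyphenyl on the nitrogen likewise gives only a 1.2-fold lower number from compound 1 to compound 4 (0.09 log units; within the scatter), so neither place has yet moved the number beyond the scatter. For 3-cyanophenyl in place of 6-methoxypyridin-3-yl only a floor can be read, an at least 1.3-fold lower number from compound 2 to compound 4 (0.13 log units; that floor lies within the scatter), and the value of compound 2 is a limit and not a number: the limit of > 50000 nM in this assay, at which 1 of the 4 values shown sits.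

Still open, going by these compounds, is whether a dimethylamino group at the end of the chain would shift the number beyond the scatter. The same question stands for a carboxylic acid on the aryl group on the nitrogen.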